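Notes on ring-amine methylation in a limit-bound series

The compounds below may be only part of what the source reports. "The series", "measured", "known", "first", "only" and "open" are said of these compounds alone.

Measured values, all in a functional assay on CCRF-CEM cells for agonist activity at C-X-C chemokine receptor type 4 (Homo sapiens), read by calcium flux, with a stated time of 25 min; a higher number here means that more compound is needed for the effect, a lower number that less compound is needed:
compound 1 `C[C@@H]1CN(c2cccc3c2C[C@H](CN(C)[C@H]2CCCc4cccnc42)NC3)C[C@H](C)N1` gives > 30000 nM
compound 2 `CN(C[C@@H]1Cc2c(cccc2N2CCNCC2)CN1)[C@H]1CCCc2cccnc21` gives > 30000 nM
compound 3 `CC(C)N(C[C@H]1Cc2c(cccc2N2CCNCC2)CN1)[C@H]1CCCc2cccnc21` gives > 30000 nM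

The value of compound 1 is a limit of this assay, not a number. The value of compound 2 is the same kind of limit. The value of compound 3 is likewise a limit. Where compound 1 stands can therefore only be stated as: at the limit, with no order among the three compounds, as the limit of > 30000 nM in this assay, at which 3 of the 3 values shown sit, shows. Going by the values given here, no step between two measured compounds is available, since no pair differs in one place.

Compound 4 `C[C@@H]1CN(c2cccc3c2C[C@H](CN(C)[C@H]2CCCc4cccnc42)NC3)C[C@H](C)N1C` differs from compound 1 by methyl in place of hydrogen on an amine nitrogen in a ring. Among the compounds with values here, with every measured value sitting at the limit, no measured step gives a direction to expect. The step expected from compound 1 to compound 4 is a step that the limit leaves unreadable from compound 1 to compound 4, that is, none beyond the scatter. Compound 4 is estimated at 50000 nM, within 15000 nM to 200000 nM, most likely reported again only as a limit.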

Compound 4, half-maximal effective concentration: > 30000 nM
Compound 4: only a limit was reported; the forecaster's own chance of this, stated with the estimate: 85%; the middle value lies beyond the limit too.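

The step from compound 1 to compound 4, methyl in place of hydrogen on an amine nitrogen in a ring, cannot be read, since both values are limits: the limit of > 30000 nM in this assay, at which 4 of the 4 values shown sit.

The compounds shown leave open whether the 3,4,5-trimethylpiperazin-1-yl group changes the concentration needed at all.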